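This account rests on a few compounds, and the source may have more. Where it says the series, first, only, none or still open, it means among the compounds named here.

Measured so far:
Compound 1, `O=C(C1CCCCC1)N1CC(c2nc(-c3cccc(F)c3)no2)C1`: 1000 nM
Compound 2, `O=C(C1CCC(F)(F)CC1)N1CC(c2nc(-c3cccc(F)c3)no2)C1`: 520 nM
Compound 3, `O=C([C@@H]1CC2CCC1C2)N1CC(c2nc(-c3cccc(F)c3)no2)C1`: 100 nM

All three share one core and differ only in the group on the carbonyl carbon. In an assay on HEK293 cells for positive allosteric modulation of metabotropic glutamate receptor 5 (Homo sapiens), read by FLIPR (on this read-out lower numbers stand for an effect already at smaller amounts and higher numbers for an effect only at larger amounts of compound), compound 3 gives 100 nM, the lowest of the three numbers: the steps into it were a 10-fold lower number from compound 1 to compound 3 (1.00 log units; beyond the scatter) and a 5.2-fold lower number from compound 2 to compound 3 (0.72 log units; beyond the scatter), while a 1.9-fold lower number from compound 1 to compound 2 (0.28 log units; within the scatter). Compound 4, `O=C(c1ccc(F)cc1)N1CC(c2nc(-c3cccc(F)c3)no2)C1`, carries a group of 7 heavy atoms (6 carbon, 1 fluorine; one six-membered aromatic ring of carbon only) in place of a group of 7 heavy atoms (7 carbon; 2 five-membered non-aromatic rings of carbon only), on a carbonyl carbon. Within the data shown here, no measured step exchanges a non-aromatic ring for an aromatic one, so the two steps into compound 3 bear on it only loosely; both lie beyond the scatter and point the same way, so leaving the two fused rings is expected to raise the number. The expected step is a 6.0-fold higher number from compound 3 to compound 4 (0.78 log units; beyond the scatter). Compound 4 is estimated at 600 nM in this assay, with a range from 150 nM to 2500 nM.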

Compound 4, half-maximal effective concentration: 2400 nM
Beside the measured number, compound 4's estimate is 4.0-fold (0.60 log units) below it, and the stated range covers the measured number.
By their numbers in this assay, from the lowest: compound 3; then compounds 2 and 1 (each within the scatter of the next); then compound 4.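

In this assay, 4-fluorophenyl on the carbonyl carbon gives a higher number than each non-aromatic group shown (a 24-fold higher number from compound 3 to compound 4 (1.38 log units; beyond the scatter); a 4.6-fold higher number from compound 2 to compound 4 (0.66 log units; beyond the scatter); a 2.4-fold higher number from compound 1 to compound 4 (0.38 log units; beyond the scatter)). The largest of these steps shows that this aromatic ring, despite having the same count of heavy atoms, does not reproduce the low number of the group in compound 3. Nothing available here accounts for these differences. The compounds shown leave open whether plain phenyl or pyridyl would behave like 4-fluorophenyl, so the effect of the ring cannot be separated from that of its fluorine.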